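Propyl in place of 2-methylphenyl in the series

The source may hold more compounds than are shown below. What is called first, only, known or untested is meant among the compounds shown, and "the series" means these compounds.

Three compounds of the series have numbers in an in vitro functional assay on cells for agonist activity at Bombesin receptor subtype-3 (Mus musculus), read by luminescence and calcium flux; a lower number here means that less compound is needed, a higher number that more compound is needed for the effect. Compound 1 `O=C(O)c1ccccc1-c1ccc(CCc2ncc(CC3CCC3)[nH]2)cc1` gives 7.1 nM, compound 2 `Cc1ccccc1Cc1cnc(CCc2ccc(-c3ccccc3C(=O)O)cc2)[nH]1` gives 9.3 nM, and compound 3 `O=C(O)c1ccccc1-c1ccc(CCc2ncc(Cc3ccc(Cl)cc3)[nH]2)cc1` gives 102 nM. Compound 2 stands second highest of the three; its nearest neighbour is compound 1, with a 1.3-fold higher number from compound 1 to compound 2 (0.12 log units; within the scatter), and its furthest is compound 3, with an 11-fold higher number from compound 2 to compound 3 (1.04 log units; beyond the scatter).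

Compound 4 `CCCCc1cnc(CCc2ccc(-c3ccccc3C(=O)O)cc2)[nH]1` is the next member, not yet measured in this assay. It differs from compound 2 in one place: propyl in place of 2-methylphenyl on a saturated chain carbon bound to an aromatic carbon.

Among the measured compounds shown here, two measured steps bear on this position. The step of a 1.3-fold higher number from compound 1 to compound 2 (0.12 log units; within the scatter) shows that exchanging cyclobutyl, a saturated group without a six-membered aromatic ring, for 2-methylphenyl made no difference beyond the scatter. The step of an 11-fold higher number from compound 2 to compound 3 (1.04 log units; beyond the scatter) and the step of a 14-fold higher number from compound 1 to compound 3 (1.16 log units; beyond the scatter) show that this position can carry a large penalty, but only 4-chlorophenyl produced it. Propyl, like cyclobutyl, brings no ring, and compound 1 sits at the low end, so the expected outcome for compound 4 is a step of no more than the scatter, a 1.3-fold higher number from compound 2 to compound 4 (0.11 log units; within the scatter).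

Compound 4 is therefore estimated at 12 nM, with a range from 5 nM to 40 nM.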

Compound 4, half-maximal effective concentration: 93 nM
Compound 4: middle estimate off by 7.8-fold (0.89 log units), on the low side; measured number above the stated range.
By their numbers in this assay, from the lowest: compounds 1 and 2 (each within the scatter of the next); then compounds 4 and 3 (each within the scatter of the next).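

Dropping the ring here is not neutral: the step of a 10-fold higher number from compound 2 to compound 4 (1.00 log units; beyond the scatter) and the step of a 13-fold higher number from compound 1 to compound 4 (1.12 log units; beyond the scatter) both lie beyond the scatter, so the penalty on this saturated chain carbon is not peculiar to 4-chlorophenyl, and the step of a 1.1-fold lower number from compound 3 to compound 4 (0.04 log units; within the scatter) puts propyl level with that group. The presence of a six-membered aromatic ring does not sort the four compounds: compound 1 has none and stands at the low end with compound 2, which has one, while compound 3 has one and stands at the high end with compound 4, which has none. Nothing on hand gives a reason for these steps.

As far as these compounds go, what cyclobutyl and 2-methylphenyl share that propyl and 4-chlorophenyl lack remains open, and an unsubstituted phenyl or a cyclopentyl group on this carbon would narrow it. From the compounds shown here alone, whether the high number holds for open chains in general also remains open, and a longer chain such as pentyl, or a branched chain such as isobutyl, would test it.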